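The source may hold more compounds than are shown below. What is called first, only, known or untested is meant among the compounds shown, and "the series" means these compounds.

Values in a functional assay on the whole organism for positive allosteric modulation, with Mus musculus as the target; a lower number here means that less compound is needed, a higher number that more compound is needed for the effect:
- Compound 1 `CCC(=O)N(c1ccc(Cl)c(Cl)c1)C1CCCC1O`: 20 mg/kg
- Compound 2 `CCC(=O)N(c1ccc(Cl)c(Cl)c1)C1CCCC1N(CC)CC`: 0.3 mg/kg
- Compound 3 `CCC(=O)N(c1ccc(Cl)c(Cl)c1)C1CCCC1N(C)Cc1ccccc1`: > 50 mg/kg

Compound 3 gives > 50 mg/kg, which is a limit of the assay and not a number.

Compound 4 `CCC(=O)N(c1ccc(Cl)c(Cl)c1)C1CCCC1N(C)CCCN(C)C` carries 2-(dimethylamino)ethyl in place of phenyl on a saturated chain carbon bound to an amine nitrogen. Cut one bond further out, this reads benzyl to 3-(dimethylamino)propyl.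

Among the measured compounds shown here, no measured step makes this exact change. The nearest steps are changes on a saturated ring carbon: an at least 160-fold higher number from compound 2 to compound 3 (2.22 log units; beyond the scatter), an at least 2.5-fold higher number from compound 1 to compound 3 (0.39 log units; beyond the scatter) and a 67-fold lower number from compound 1 to compound 2 (1.82 log units; beyond the scatter). In this assay, changes at that carbon have therefore moved the number strongly in both directions. Like compound 2 at 0.3 mg/kg, compound 4 has no phenyl in this group, but the two groups still differ, so only part of the gap is expected to close.

The expected outcome is a clear move to a lower number, an at least 5.0-fold lower number from compound 3 to compound 4 (0.69 log units; beyond the scatter), although a reading at the limit remains possible. For compound 4 the estimated value is 10 mg/kg, with an expected range of 1.5 mg/kg to 50 mg/kg.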

Compound 4, dose for half-maximal effect: 30 mg/kg
Compound 4: the middle estimate sits 3.0-fold (0.48 log units) below what was measured; measured number inside the range.
By their numbers in this assay, from the lowest: compound 2; then compounds 1 and 4 (each within the scatter of the next). At a limit, above all of these: compound 3.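

In this assay, 2-(dimethylamino)ethyl in place of phenyl on a saturated chain carbon bound to an amine nitrogen gives an at least 1.6-fold lower number from compound 3 to compound 4 (0.22 log units; that floor lies within the scatter), so this pair alone secures no gain from losing the aromatic ring. Compound 3 is held at a limit and not a number: the limit of > 50 mg/kg in this assay, at which 1 of the 4 values shown sits. The new information lies at the saturated ring carbon, where an amine alone does not give the low number of the diethylamino compound: the change gives a 100-fold higher number from compound 2 to compound 4 (2.00 log units; beyond the scatter), while against hydroxy it gives a 1.5-fold higher number from compound 1 to compound 4 (0.18 log units; within the scatter), so no difference from hydroxy can be read.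

On these data alone, it remains open whether the low number of compound 2 depends on the ethyl groups themselves or on the small size of the whole amine. A pyrrolidine or a piperidine at the same ring carbon would bear on that question.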